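The source may report more compounds than this note shows. Statements on the series, on what has been measured and on what is new or still open speak of the compounds shown alone.

Measured compounds in a functional assay on NPC-TW01 cells (Homo sapiens) for inhibition, read by MTT assay, with a stated time of 72 h; on this read-out lower numbers stand for stronger inhibition of growth and higher numbers for weaker inhibition of growth:

compound 1 `CCc1nc(C(=O)OC)nn1-c1ccc(F)cc1` — compound 1 gives 15800 nM
compound 2 `COC(=O)c1nc(C(C)C)n(-c2ccc(F)cc2)n1` — for compound 2 the assay reports only a limit, > 100000 nM
compound 3 `COC(=O)c1nc(C2CC2)n(-c2ccc(F)cc2)n1` — compound 3 gives 95900 nM

Compound 3 holds the highest of the two numbers shown; the nearest number is that of compound 1, and the step of a 6.1-fold higher number from compound 1 to compound 3 (0.78 log units; beyond the scatter) runs beyond the scatter. The third value is a limit: the limit of > 100000 nM in this assay, at which 1 of the 3 values shown sits, and the comparison an at least 1.0-fold lower number from compound 2 to compound 3 (0.01 log units; that floor lies within the scatter) is therefore only a floor that sits within the scatter, so nothing can be said about order between compound 2 and compound 3.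

Compound 4 `COC(=O)c1nc(C2CCCC2)n(-c2ccc(F)cc2)n1` is not yet measured. It differs from compound 3 in one place: cyclopentyl in place of cyclopropyl on an aromatic carbon. Going by the values given here, the steps that bear on it are the two changes of the group on that aromatic carbon, a 6.1-fold higher number from compound 1 to compound 3 (0.78 log units; beyond the scatter) and an at least 1.0-fold lower number from compound 2 to compound 3 (0.01 log units; that floor lies within the scatter), the first a modest rise in number, the second a floor within the scatter. Both branched and ring groups there sit at or near the limit, so for compound 4 no step beyond the scatter is expected in this assay , and the expected step is a 1.3-fold higher number from compound 3 to compound 4 (0.10 log units; within the scatter), with a fair chance that only a limit is reported. Compound 4 is expected at about 120000 nM, in the range 40000 nM to 300000 nM.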

Compound 4, concentration for 50% growth inhibition: 10400 nM
Estimate against measurement, compound 4: 12-fold (1.06 log units) above; the measured number lies below the stated range.
By their numbers in this assay, from the lowest: compounds 4 and 1 (each within the scatter of the next); then compound 3. At a limit, above all of these: compound 2.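

At the aromatic carbon bearing the changed group, the ring size matters in this assay: a 9.2-fold lower number from compound 3 to compound 4 (0.96 log units; beyond the scatter), so a ring group here does not by itself place a compound near the limit of the assay. Compound 2 carries only a limit, and an at least 9.6-fold lower number from compound 2 to compound 4 (0.98 log units; beyond the scatter) is therefore a floor: the limit of > 100000 nM in this assay, at which 1 of the 4 values shown sits. With a 1.5-fold lower number from compound 1 to compound 4 (0.18 log units; within the scatter), cyclopentyl and ethyl cannot be told apart, so the added carbon atoms of cyclopentyl over cyclopropyl do not cost activity, and no steady trend with group size holds across the four compounds.

On these data alone, whether a cyclobutyl group, a cyclohexyl group or a longer chain such as butyl would track compound 4 or compound 3 remains open. Also open, as far as these compounds go, is what a carboxylic acid or an amide in place of the methoxycarbonyl group would do in this assay.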